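Swapping the nitro group for a bulky tert-butylphenyl ring

The source may report more compounds than this note shows. Statements on the series, on what has been measured and on what is new or still open speak of the compounds shown alone.

Compound 1 `COc1cc2nc(N3CCN(S(=O)(=O)c4ccc([N+](=O)[O-])cc4)CC3)nc(N)c2cc1OC` is measured in a functional assay on PC-3 cells (Homo sapiens) for inhibition (on this read-out higher numbers stand for weaker inhibition and lower numbers for stronger inhibition), and gives 36000 nM, the lowest of the three numbers but within the scatter of both others. Compound 2 `COc1cc2nc(N3CCN(S(=O)(=O)c4cc(Cl)ccc4Cl)CC3)nc(N)c2cc1OC` gives 60000 nM and compound 3 `COc1cc2nc(N3CCN(S(=O)(=O)c4cc(C(=O)O)c(Cl)cc4Cl)CC3)nc(N)c2cc1OC` gives 52000 nM. Compound 4 `COc1cc2nc(N3CCN(S(=O)(=O)c4ccc(-c5ccc(C(C)(C)C)cc5)cc4)CC3)nc(N)c2cc1OC` carries 4-(tert-butyl)phenyl in place of nitro on an aromatic carbon, placed on an aromatic carbon of a six-membered aromatic ring of carbon only, para to a large group. Among the compounds with values here, no measured step changes exactly this group. The steps of a 1.7-fold higher number from compound 1 to compound 2 (0.22 log units; within the scatter) and a 1.4-fold higher number from compound 1 to compound 3 (0.16 log units; within the scatter) show that varying the ring on the sulfonyl sulfur left this assay essentially unchanged. A step of similar size is therefore expected, a 1.2-fold lower number from compound 1 to compound 4 (0.08 log units; within the scatter). For compound 4 the estimate is 30000 nM, within 8000 nM to 120000 nM.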

Compound 4, half-maximal inhibitory concentration: 10000 nM
For compound 4 the middle estimate is 3.0-fold (0.48 log units) above the measured one; low and high end bracket the measured number.
By their numbers in this assay, from the lowest: compound 4; then compounds 1, 3 and 2 (each within the scatter of the next).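

In this assay, 4-(tert-butyl)phenyl in place of nitro gives a 3.6-fold lower number from compound 1 to compound 4 (0.56 log units; beyond the scatter). Within the data shown here, this is the first step to pass beyond the scatter, whereas the earlier changes of the ring on the sulfonyl sulfur did not. This aromatic carbon therefore accepts a much larger, all-carbon group, 10 heavy atoms against 3, and inhibition becomes modestly stronger rather than being lost.

From the compounds shown here alone, whether the second ring or the tert-butyl carries this change stays open, and a plain phenyl or an amine at this carbon would help separate them. Nothing measured here explains the change.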